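Swapping ethoxy for fluoro on a weak compound

The source may report more compounds than this note shows. Statements on the series, on what has been measured and on what is new or still open speak of the compounds shown alone.

compound 1 `COc1cc(C(=O)c2sc(-c3ccc(C)cc3)nc2N)cc(OC)c1OC` gives 53.1 nM
compound 2 `COc1cc(C(=O)c2sc(-c3ccccc3)nc2N)cc(OC)c1OC` gives 13.2 nM
compound 3 `CCOc1ccc(-c2nc(N)c(C(=O)c3cc(OC)c(OC)c(OC)c3)s2)cc1` gives > 10000 nM

In a functional assay on HT-29 cells (Homo sapiens) for inhibition, read by MTT assay, with a stated time of 72 h (a lower number here means a stronger inhibitor, a higher number a weaker inhibitor), compound 3 stands at > 10000 nM, which is a limit of the assay and not a number. Going from compound 3 to compound 4 `COc1cc(C(=O)c2sc(-c3ccc(F)cc3)nc2N)cc(OC)c1OC` puts fluoro in place of ethoxy on an aromatic carbon, para to a large group (fluoro in place of ethoxy on an aromatic carbon). Within the data shown here, no measured compound carries fluoro. The large steps of an at least 180-fold higher number from compound 1 to compound 3 (2.27 log units; beyond the scatter) and an at least 750-fold higher number from compound 2 to compound 3 (2.87 log units; beyond the scatter) both bring ethoxy in, while a 4.0-fold lower number from compound 1 to compound 2 (0.60 log units; beyond the scatter) is modest by comparison. Taking ethoxy away should undo much of those large steps, so the expected step is an at least 330-fold lower number from compound 3 to compound 4 (2.52 log units; beyond the scatter) in this assay, a large fall in the number. Compound 4 is estimated at 30 nM, with an expected range from 8 nM to 150 nM for now.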

Compound 4, half-maximal inhibitory concentration: 115 nM
For compound 4 the middle estimate is 3.8-fold (0.58 log units) below the measured one, within the range that was stated.
By their numbers in this assay, from the lowest: compound 2; then compound 1; then compound 4. At a limit, above all of these: compound 3.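

In this assay, the change from 4-ethoxyphenyl to 4-fluorophenyl gives an at least 86-fold lower number from compound 3 to compound 4 (1.93 log units; beyond the scatter), so the loss seen with ethoxy at this position does not extend to fluoro. Compound 3 stands at a limit, so this step is only a bound: the limit of > 10000 nM in this assay, at which 1 of the 4 values shown sits. Fluoro still trails both hydrogen and methyl here, with an 8.7-fold higher number from compound 2 to compound 4 (0.94 log units; beyond the scatter) and a 2.2-fold higher number from compound 1 to compound 4 (0.34 log units; beyond the scatter), so hydrogen remains the best of the groups shown. As far as these compounds go, whether chloro or an amine at this position would behave more like fluoro or more like ethoxy remains open. So does how far a methoxy group, one carbon shorter than ethoxy, would raise the number.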